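A few compounds are considered here, and "the series" means these few. Any claim that something is new, unique, unknown or untested is made for them only; others in the source may bear on it.

Measured so far:
- compound 1, `CO[C@@H]1C[C@@H](C(=O)NCCN(C)C)N(C(=O)NCc2ccc(C(=O)N3CCCCc4sccc43)cc2Cl)C1`: 1800 nM in an assay on isolated protein with Vasopressin V2 receptor (Homo sapiens) as the target; a higher number here means that more compound is needed for the effect, a lower number that less compound is needed
- compound 2, `Cc1cc(C(=O)N2CCCCc3sccc32)ccc1CNC(=O)N1CCC[C@H]1C(=S)N1CCCN(C)CC1`: 890 nM in this assay

Compound 1 has the higher of the two numbers; compound 2 sits lower, and that gap is beyond the scatter. Compound 3, `CO[C@@H]1C[C@@H](C(=O)N2CCC(N3CCCCC3)CC2)N(C(=O)NCc2ccc(C(=O)N3CCCCc4sccc43)cc2Cl)C1`, is not yet measured. It differs from compound 1 in one place: 4-(piperidin-1-yl)piperidin-1-yl in place of (2-(dimethylamino)ethyl)amino on a carbonyl carbon. Among the compounds with values here, no measured pair shows this kind of change, so only a rough expectation is possible. A modest step downward, from compound 1 to compound 3, of about a 2.3-fold lower number from compound 1 to compound 3 (0.35 log units; beyond the scatter) is expected. Compound 3 is thus estimated at 800 nM, within a range of 250 nM to 3000 nM.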

Compound 3, half-maximal effective concentration: 1200 nM
Compound 3: middle estimate off by 1.5-fold (0.18 log units), on the low side, and the stated range covers the measured number.
By their numbers in this assay, from the lowest: compounds 2, 3 and 1 (each within the scatter of the next, the first and the last beyond it).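

In this assay, putting 4-(piperidin-1-yl)piperidin-1-yl in place of (2-(dimethylamino)ethyl)amino on this carbonyl carbon gives a 1.5-fold lower number from compound 1 to compound 3 (0.18 log units; within the scatter). The entering group has two six-membered non-aromatic rings and no hydrogen-bond donor, while the leaving group has no ring and one donor. This position therefore accepts a large change in the group without a change beyond the scatter.

Going by these compounds, whether a morpholin-4-yl group or a simple hydroxyl on this carbonyl carbon would shift the number beyond the scatter remains open. No evidence on hand explains why this exchange leaves the number within the scatter.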